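Aryl Urea Swap on a Cyclohexyl Ether Scaffold

A few compounds are considered here, and "the series" means these few. Any claim that something is new, unique, unknown or untested is made for them only; others in the source may bear on it.

Compound 1 `O=C(Nc1ccc(Br)cc1)N[C@H]1CC[C@H](Oc2ccc(F)cc2)CC1`: > 20000 nM
Compound 2 `COc1ccc(NC(=O)N[C@H]2CC[C@H](Oc3ccc(F)cc3)CC2)cc1`: > 20000 nM

In a functional assay on CRL2813 cells (Homo sapiens) for cytotoxicity, read by sulforhodamine B assay, with a stated time of 5 days (a higher number here means a weaker inhibitor, a lower number a stronger inhibitor), compound 1 gives > 20000 nM, a limit of the assay. In this assay compound 2 gives > 20000 nM, likewise a limit. The step that the two limits leave unreadable from compound 1 to compound 2 is therefore unreadable, as the limit of > 20000 nM in this assay, at which 2 of the 2 values shown sit, shows; compound 2 stands only at a limit. Compound 3 `O=C(Nc1ccccc1Cl)N[C@H]1CC[C@H](Oc2ccc(F)cc2)CC1` differs by 2-chlorophenyl in place of 4-methoxyphenyl on an amide-type nitrogen. Within the data shown here, no measured step reads, so nothing points to a change beyond the scatter. Compound 3 is expected to remain near the limit, estimated at 20000 nM (range 8000 nM to 50000 nM). The expected step is a number no higher from compound 2 to compound 3 (the limit leaves the size open).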

Compound 3, half-maximal inhibitory concentration: 9100 nM
The estimate for compound 3 lay 2.2-fold (0.34 log units) above the measured number; low and high end bracket the measured number.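

Compound 3 shows that the aryl group on the amide-type nitrogen can move the read-out in this assay, which the earlier pair could not show. 2-Chlorophenyl in place of 4-methoxyphenyl gives an at least 2.1-fold lower number from compound 2 to compound 3 (0.34 log units; beyond the scatter), and 2-chlorophenyl in place of 4-bromophenyl gives an at least 2.1-fold lower number from compound 1 to compound 3 (0.34 log units; beyond the scatter). The full size of each step stays open, as compound 1 and compound 2 sit at a limit: the limit of > 20000 nM in this assay, at which 2 of the 3 values shown sit.

The compounds shown leave open whether the chlorine or its place in 2-chlorophenyl matters. A 4-chlorophenyl or unsubstituted phenyl group on this nitrogen would separate the two.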